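Aryl piperazine dithiocarbamate benzamides: methoxy to methyl

A few compounds are considered here, and "the series" means these few. Any claim that something is new, unique, unknown or untested is made for them only; others in the source may bear on it.

Measured so far in a functional assay on MGC-803 cells (Homo sapiens) for antiproliferative activity, read by CCK-8 assay, with a stated time of 72 h, tested at 2 uM; on this read-out higher numbers stand for a stronger effect at the one concentration tested and lower numbers for a weaker effect:
compound 1 `CN(C(=S)SCc1ccc(C(=O)Nc2ccccc2N)cc1)c1cccnc1` gives 46.1%
compound 2 `COc1ccc(N2CCN(C(=S)SCc3ccc(C(=O)Nc4ccccc4N)cc3)CC2)cc1` gives 25.3%
compound 3 `CC1CCN(C(=S)SCc2ccc(C(=O)Nc3ccccc3N)cc2)CC1` gives 28.1%

In this assay compound 2 gives 25.3%, which is within the scatter of compound 3 and beyond the scatter of compound 1. Within the data shown here, the one measured step changes the group on the thiocarbonyl carbon: a number 18 percentage points lower from compound 1 to compound 3 (beyond the scatter). That step exchanges the whole amine part and says nothing about a substituent on the aryl ring of an aryl piperazine.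

Compound 4 `Cc1ccc(N2CCN(C(=S)SCc3ccc(C(=O)Nc4ccccc4N)cc3)CC2)cc1` is not yet measured. It differs from compound 2 in one place: methyl in place of methoxy on an aromatic carbon. Among the measured compounds shown here, no measured pair shows this change or any other change on that ring, so there is no step to lean on. The replacement is small, and for compound 4 a step that stays within the scatter is expected, a number 1.7 percentage points higher from compound 2 to compound 4 (within the scatter). In this assay compound 4 is therefore estimated at 27%, with a range from 15% to 40%.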

Compound 4, a percentage reported as inhibition, at one concentration (the size of the read-out at that concentration, not a potency): 33.4%
Compound 4: the middle estimate sits 6.4 percentage points below what was measured; the measured number falls inside the stated range.
By their numbers in this assay, from the lowest: compounds 2, 3 and 4 (each within the scatter of the next); then compound 1.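

In this assay, among these compounds, the first step on the aromatic ring of this series, 4-methoxyphenyl to 4-methylphenyl, gives a number 8.1 percentage points higher from compound 2 to compound 4 (within the scatter). At this position, para to a large group, the loss of the methoxy oxygen and its hydrogen-bond acceptor therefore does not separate the two compounds, whereas the earlier step changed the whole amine part. No available evidence accounts for this result.

Among the compounds shown here, the single pair covers only methoxy and methyl, so it remains open whether an amine, a carboxylic acid or a longer chain at the same position would give a step beyond the scatter. On these data alone, it also remains open whether the two compounds would stay this close at other concentrations, as the read-out reflects the size of the effect at one concentration and not potency.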